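The compounds below may be only part of what the source reports. "The series", "measured", "known", "first", "only" and "open" are said of these compounds alone.

Measured compounds in a functional assay on NCI-H460 cells (Homo sapiens) for inhibition, read by sulforhodamine B assay, with a stated time of 48 h, tested at 10 uM; on this read-out higher numbers stand for more inhibition at the one concentration tested (going by the name of the read-out) and lower numbers for less inhibition:
- compound 1 `O=Cc1ccc(-c2cn3ccnc3c(-c3ccc4ncn(C5CCCCC5)c4c3)n2)cc1`: 37.8%
- compound 2 `c1ccc2c(-c3cn4ccnc4c(-c4ccc5ncn(C6CCCCC6)c5c4)n3)cccc2c1`: 3.61%
- compound 3 `COc1ccccc1-c1cn2ccnc2c(-c2ccc3ncn(C4CCCCC4)c3c2)n1`: 9.62%

Compound 3 stands second highest of the three numbers in this assay; its nearest neighbour is compound 2, lower by a number 6 percentage points higher from compound 2 to compound 3 (within the scatter) reckoned the other way, a gap within the scatter, and its furthest is compound 1, which sits higher by a margin beyond the scatter, a number 28.2 percentage points lower from compound 1 to compound 3 (beyond the scatter).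

Compound 4 `c1csc(-c2cn3ccnc3c(-c3ccc4ncn(C5CCCCC5)c4c3)n2)c1` differs from compound 3 in one place: thiophen-2-yl in place of 2-methoxyphenyl on an aromatic carbon. For the measured compounds named here, the steps that bear on this position are the two from compound 1, a number 34.2 percentage points lower from compound 1 to compound 2 (beyond the scatter) and a number 28.2 percentage points lower from compound 1 to compound 3 (beyond the scatter), both moving away from the 4-formylphenyl group and both lowering inhibition beyond the scatter, while the exchange of naphthalen-1-yl for 2-methoxyphenyl, a number 6 percentage points higher from compound 2 to compound 3 (within the scatter), stayed within it. Going by the values given here, no measured step introduces thiophen-2-yl, and the expectation rests on the two non-formyl neighbours both sitting low and close together. The expected step is a number 0.4 percentage points higher from compound 3 to compound 4 (within the scatter). For compound 4 the estimated value in this assay is 10%, expected between 0% and 35%.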

Compound 4, a percentage reported as inhibition, at one concentration (the size of the read-out at that concentration, not a potency): 1.3%
Compound 4: middle estimate off by 8.7 percentage points, on the high side; measured number inside the range.
By their numbers in this assay, from the lowest: compounds 4, 2 and 3 (each within the scatter of the next); then compound 1.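

In this assay, thiophen-2-yl gives a number 8.3 percentage points lower from compound 3 to compound 4 (within the scatter) and a number 2.3 percentage points lower from compound 2 to compound 4 (within the scatter), so a five-membered aromatic ring with 1 hetero atom at this position cannot be told apart from 2-methoxyphenyl or naphthalen-1-yl. The third step, a number 36.5 percentage points lower from compound 1 to compound 4 (beyond the scatter), leaves 4-formylphenyl apart from all three other groups, and the low readings now span a group of 5 heavy atoms as well as 2-methoxyphenyl with 8. No measurement on hand accounts for this pattern.

The compounds shown leave open whether the higher number of compound 1 depends on the formyl group itself or would hold for other substituted phenyl rings. A phenyl ring bearing an acetyl group, a nitrile or a carboxylic acid in place of the formyl group would separate these readings.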